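This account rests on a few compounds, and the source may have more. Where it says the series, first, only, none or still open, it means among the compounds named here.

Compounds that share one core can differ only in the aryl group on an amide-type nitrogen, and that group is what varies here. In a functional assay on MDA-MB-231 cells (Homo sapiens) for cytotoxicity, read by MTT assay, with a stated time of 72 h (on this read-out lower numbers stand for stronger inhibition and higher numbers for weaker inhibition), compound 1 `O=C(CN1CCN(c2nnc(Cc3ccncc3)c3ccccc23)CC1)Nc1cccc(F)c1` gives 4.4 nM, compound 2 `O=C(CN1CCN(c2nnc(Cc3ccncc3)c3ccccc23)CC1)Nc1ccc(F)c(C(F)(F)F)c1` gives 1.9 nM, and compound 3 `O=C(CN1CCN(c2nnc(Cc3ccncc3)c3ccccc23)CC1)Nc1ccc(F)c(Cl)c1` gives 4 nM. Compound 3 therefore stands level with compound 1 within the scatter, as a 1.1-fold lower number from compound 1 to compound 3 (0.04 log units; within the scatter) shows, while compound 2 holds the lowest number.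

The next structure, compound 4 `O=C(CN1CCN(c2nnc(Cc3ccncc3)c3ccccc23)CC1)Nc1cc(C(F)(F)F)ccc1Cl`, has not been measured. It differs from compound 3 by 2-chloro-5-(trifluoromethyl)phenyl in place of 3-chloro-4-fluorophenyl on an amide-type nitrogen, with 2-chloro-5-(trifluoromethyl)phenyl in place of 3-chloro-4-fluorophenyl on an amide-type nitrogen.

Among the compounds with values here, two measured steps bear on this change, and both involve compound 2, which carries a trifluoromethyl group. They are a 2.3-fold lower number from compound 1 to compound 2 (0.36 log units; beyond the scatter) and a 2.1-fold higher number from compound 2 to compound 3 (0.32 log units; beyond the scatter), and both are modest. They hint that trifluoromethyl may go with a slightly lower number. However, no measured compound carries this exact substitution pattern, so the hint is weak. The expected step is a 1.3-fold lower number from compound 3 to compound 4 (0.12 log units; within the scatter), which means a small drop at most and probably none beyond the scatter. For compound 4 the estimated value is 3 nM, with an expected range of 1 nM to 10 nM.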

Compound 4, half-maximal inhibitory concentration: 3.7 nM
Compound 4: the middle estimate sits 1.2-fold (0.09 log units) below what was measured; the range from low to high includes it.
By their numbers in this assay, from the lowest: compounds 2, 4, 3 and 1 (each within the scatter of the next, the first and the last beyond it).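

In this assay, placing 2-chloro-5-(trifluoromethyl)phenyl on the amide-type nitrogen, a group with more heavy atoms than 3-chloro-4-fluorophenyl, leaves the result within the scatter, as a 1.1-fold lower number from compound 3 to compound 4 (0.03 log units; within the scatter) shows, so this position accepts the larger group without a clear change. Carrying a trifluoromethyl group does not by itself set a compound apart: compound 4 and compound 2 both carry one, yet a 1.9-fold higher number from compound 2 to compound 4 (0.29 log units; within the scatter) stays within the scatter, and a 1.2-fold lower number from compound 1 to compound 4 (0.08 log units; within the scatter) also stays within it, although compound 1 has no trifluoromethyl group. Compound 4 therefore lies within the scatter of all three earlier compounds, even though compound 1 and compound 2 lie beyond the scatter of each other.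

No supporting measurement here explains these numbers. The compounds shown also leave open whether the low values would hold with an amine or a carboxylic acid on the aromatic ring, or with a longer chain in place of the aryl group on the amide-type nitrogen.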